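From an Aryl Amide to an Aryl Urea on a Shared Core

This account rests on a few compounds, and the source may have more. Where it says the series, first, only, none or still open, it means among the compounds named here.

Compound 1, `CN(C(=O)C(C)(C)C)c1ccc2[nH]c(-c3n[nH]c4ccccc34)cc2n1`: 4990 nM
Compound 2, `CN(C(=O)c1ccc(Cl)cc1)c1ccc2[nH]c(-c3n[nH]c4ccccc34)cc2n1`: 450 nM
Compound 3, `COc1cccc(C(=O)N(C)c2ccc3[nH]c(-c4n[nH]c5ccccc45)cc3n2)c1`: 1420 nM

Three compounds share one core and differ only in the group attached to the carbonyl carbon of a methyl-substituted amide. In a functional assay on HL-60 cells (Homo sapiens) for antiproliferative activity, read by MTT assay, with a stated time of 72 h (a lower number here means a stronger inhibitor, a higher number a weaker inhibitor), compound 1, which carries a tert-butyl group there, gives the weakest result of the three. Replacing that group by an aromatic ring helps: an 11-fold lower number from compound 1 to compound 2 (1.04 log units; beyond the scatter) and a 3.5-fold lower number from compound 1 to compound 3 (0.55 log units; beyond the scatter). Between the two aromatic groups, a 3.2-fold higher number from compound 2 to compound 3 (0.50 log units; beyond the scatter). Compound 3 thus stands in the middle of the three numbers in this assay, closer to compound 2 than to compound 1.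

Compound 4, `COc1ccc(NC(=O)N(C)c2ccc3[nH]c(-c4n[nH]c5ccccc45)cc3n2)cc1`, has not yet been measured. It differs from compound 3 by a single change: (4-methoxyphenyl)amino in place of 3-methoxyphenyl on a carbonyl carbon. Going by the values given here, this turns an aryl amide into an aryl urea, and no measured pair shows the effect of inserting an amino group at this position. The steps from compound 1 show that an aromatic group on the carbonyl carbon is tolerated, but the swap of aromatic groups between compound 2 and compound 3 was only modest. No step beyond the usual scatter is therefore expected for compound 4, and its estimated value in this assay is 1500 nM, between 400 nM and 6000 nM, meaning a 1.1-fold higher number from compound 3 to compound 4 (0.02 log units; within the scatter).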

Compound 4, half-maximal inhibitory concentration: 7.9 nM
Compound 4: middle estimate off by 190-fold (2.28 log units), on the high side; measured number below the stated range.
By their numbers in this assay, from the lowest: compound 4; then compound 2; then compound 3; then compound 1.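

Inserting an amino group at this position has a far larger effect than any of the earlier changes on the carbonyl carbon suggested: in this assay the urea gives a 180-fold lower number from compound 3 to compound 4 (2.25 log units; beyond the scatter), a bigger step than any among compound 1, compound 2 and compound 3. The gain is not tied to compound 3 as a poor starting point, since the urea also shows a 57-fold lower number from compound 2 to compound 4 (1.76 log units; beyond the scatter) against the best of the amides and a 630-fold lower number from compound 1 to compound 4 (2.80 log units; beyond the scatter) against the tert-butyl amide, which puts compound 4 at the lowest number of the four, with every step beyond the scatter. No measurement available here explains why this change has so large an effect.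

The step to compound 4 brings in the amino group and also moves the methoxy group from the 3-position of the ring to the 4-position, so a (3-methoxyphenyl)amino group or a plain 4-methoxyphenyl group on the carbonyl carbon would be needed to tell which part matters. With only one urea among these compounds, it also stays open whether another urea, such as one carrying a (4-chlorophenyl)amino group, would behave the same way.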